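Adding Methoxy to the Phenyl Amide of Compound 3

The source may hold more compounds than are shown below. What is called first, only, known or untested is meant among the compounds shown, and "the series" means these compounds.

Compound 1 `C=CC1=C(C(=O)NCCC)C(c2ccc(Cl)c(Cl)c2)OC1` gives 31300 nM in a functional assay on QGY7701 cells (Homo sapiens) for cytotoxicity, read by MTT assay, with a stated time of 24 h; on this read-out lower numbers stand for stronger inhibition and higher numbers for weaker inhibition.
Compound 2 `C=CC1=C(C(=O)NCC(C)C)C(c2ccc(Cl)c(Cl)c2)OC1` gives in this assay > 100000 nM, a limit of the assay and not a number.
Compound 3 `C=CC1=C(C(=O)Nc2ccccc2)C(c2ccc(Cl)c(Cl)c2)OC1` gives in this assay > 100000 nM, again a limit of the assay rather than a number.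

So compound 3 stands at the limit, where two of the three values sit (the limit of > 100000 nM in this assay, at which 2 of the 3 values shown sit), and only compound 1 yields a number. Compound 4 `C=CC1=C(C(=O)Nc2ccccc2OC)C(c2ccc(Cl)c(Cl)c2)OC1` differs from compound 3 by methoxy in place of hydrogen on an aromatic carbon. For the measured compounds named here, no measured step alters this phenyl ring itself; the steps leading into compound 3 were an at least 3.1-fold higher number from compound 1 to compound 3 (0.50 log units; beyond the scatter) and a step that the two limits leave unreadable from compound 2 to compound 3, neither of which speaks to a methoxy. Compound 4 is therefore expected to stay at or near the limit, a step of a number no higher from compound 3 to compound 4 (the limit leaves the size open). Compound 4 is estimated at 100000 nM, between 30000 nM and 300000 nM.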

Compound 4, half-maximal inhibitory concentration: > 100000 nM
Compound 4: only a limit was reported; the forecaster's own chance of this, stated with the estimate: 70%; the middle value sits exactly at the limit.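

Placing a methoxy on this phenyl ring does not bring the compound into the range where the assay gives a number: > 100000 nM for compound 4 is a limit of the assay. For the compounds shown here, the steps from compound 2 and compound 3 to compound 4 cannot be read, whereas the one readable step is an at least 3.1-fold higher number from compound 1 to compound 4 (0.50 log units; beyond the scatter). The series now rests largely on one boundary: the limit of > 100000 nM in this assay, at which 3 of the 4 values shown sit.

As far as these compounds go, whether an amine or a carboxylic acid on this phenyl ring would give a number stays open. So does the effect of a longer chain in place of the propyl of compound 1.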